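Benzyl in Place of Isopentyl: Expected Cytotoxicity of Compound 3

A few compounds are considered here, and "the series" means these few. Any claim that something is new, unique, unknown or untested is made for them only; others in the source may bear on it.

The study covers two measured compounds and one that has not yet been tested. In an ADME assay on Huh-7 cells (Homo sapiens) for cytotoxicity, with a stated time of 72 h (on this read-out higher numbers stand for lower toxicity in this test and lower numbers for higher toxicity in this test), compound 1 `CC(C)(C)CCN1C(=O)C(C2=NS(=O)(=O)c3cc(NS(C)(=O)=O)ccc3N2)=C(O)C2CCCCCCC21` gives "not determined" (no result reported); its result is simply absent. Compound 2 `CC(C)CCN1C(=O)C(C2=NS(=O)(=O)c3cc(NS(C)(=O)=O)ccc3N2)=C(O)C2CCCC21` was examined, and in this assay compound 2 gives > 1000 nM, which is a limit of the assay rather than a measured number. As the evidence shows, (the limit of > 1000 nM in this assay, at which 1 of the 2 values shown sits). So compound 2 stands at the limit, with compound 1 offering no number to compare against, and no step between measured compounds is available.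

Compound 3 `CS(=O)(=O)Nc1ccc2c(c1)S(=O)(=O)N=C(C1=C(O)C3CCCC3N(Cc3ccccc3)C1=O)N2` differs from compound 2 in one place: phenyl in place of isobutyl on a saturated chain carbon bound to an amide-type nitrogen in a ring. For the measured compounds named here, no measured step in this assay informs the size of such a change, so no direction beyond the scatter can be asserted from the data.

Given that compound 2 sits at the limit, compound 3 is expected to remain near or at that limit, corresponding to a step that the limit leaves unreadable from compound 2 to compound 3 that is not expected to rise beyond the scatter. Compound 3 is therefore estimated at 1500 nM, within a range from 600 nM to 6000 nM.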

Compound 3, half-maximal cytotoxic concentration: > 33000 nM
Compound 3 ended at the assay's limit; the forecaster's own chance of this, stated with the estimate: 75%; middle value at least 22-fold (1.34 log units) away from the limit.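

In this assay compound 2 gives > 1000 nM as a limit of the assay. Compound 3 gives > 33000 nM as a limit as well. For the compounds shown here, with only these two limits, no step between compound 2 and compound 3 can be read. The compounds shown leave open whether isopentyl to benzyl changes this read-out at all, and in which direction.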